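A few compounds are considered here, and "the series" means these few. Any claim that something is new, unique, unknown or untested is made for them only; others in the source may bear on it.

Compound 1, `O=c1[nH]c(-c2cccc3ccccc23)nc2ccc(N3CCCCC3)cc12`: > 50000 nM
Compound 2, `Cc1ccc2c(=O)[nH]c(-c3ccccc3N(C)C)nc2c1`: 4430 nM

In a functional assay on T47D cells (Homo sapiens) for cytotoxicity, read by MTT assay, with a stated time of 2 days (on this read-out higher numbers stand for weaker inhibition and lower numbers for stronger inhibition), compound 1 gives > 50000 nM, which is a limit of the assay rather than a measured number. Going by the values given here, compound 2 gives 4430 nM in this assay, the only number among the two values shown, the other sitting at the limit of > 50000 nM in this assay, at which 1 of the 2 values shown sits. Compound 3, `Cc1ccc2c(=O)[nH]c(-c3ccccc3F)nc2c1`, has not yet been measured; it differs from compound 2 by fluoro in place of dimethylamino on an aromatic carbon. Among the compounds with values here, no step between measured compounds is available to calibrate this change, so the expectation is uncertain; a modest weakening in this assay is expected, a 2.0-fold higher number from compound 2 to compound 3 (0.31 log units; beyond the scatter). Compound 3 is estimated at 9000 nM, with a range from 2000 nM to 40000 nM.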

Compound 3, half-maximal inhibitory concentration: > 50000 nM
Compound 3: no number, only a limit; the forecaster's own chance of this, stated with the estimate: 20%; middle value at least 5.5-fold (0.74 log units) away from the limit.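

In this assay, the group on this aromatic carbon, ortho to a large group, clearly counts: fluoro in place of dimethylamino gives an at least 11-fold higher number from compound 2 to compound 3 (1.05 log units; beyond the scatter). Compound 3 gives > 50000 nM, which is a limit of the assay and not a number. The true size of the step therefore stays unknown, and only its minimum can be read: the limit of > 50000 nM in this assay, at which 2 of the 3 values shown sit.

The compounds shown leave open whether dimethylamino itself is needed here, or whether another group on this carbon, such as methoxy or a plain amine, would also give a measurable value.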